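The source may hold more compounds than are shown below. What is called first, only, known or untested is meant among the compounds shown, and "the series" means these compounds.

Compound 1 `Nc1ccccc1NC(=O)c1ccc(CNC2=N[C@H](Cc3ccccc3)CS2)cc1` was measured in an assay on isolated protein for inhibition of protein deacetylase HDAC6 (Homo sapiens), read by fluorescence, with stated times of 3 h and 60 min; a lower number here means a stronger inhibitor, a higher number a weaker inhibitor. In this assay compound 1 gives only a limit, > 20000 nM.
Compound 2 `Nc1cc(O)ccc1NC(=O)c1ccc(CNc2nccc(-c3cccnc3)n2)cc1` gives only a limit in this assay, > 20000 nM.
Compound 3 `Nc1cc(C(=O)OCc2ccccc2)ccc1NC(=O)c1ccc(CNc2nccc(-c3cccnc3)n2)cc1` gives only a limit in this assay, > 20000 nM.

Compound 3 therefore stands at the limit, where all three measured values sit (the limit of > 20000 nM in this assay, at which 3 of the 3 values shown sit). Going by the values given here, the one measured step, a step that the two limits leave unreadable from compound 2 to compound 3, is unreadable, since both ends are limits. The next compound, compound 4 `Nc1cc(C(=O)O)ccc1NC(=O)c1ccc(CNc2nccc(-c3cccnc3)n2)cc1`, differs from compound 3 by hydrogen in place of benzyl on an oxygen next to a carbonyl group. Among the compounds with values here, no measured step bears on this change, so no direction can be read from the data. Compound 4 is expected to remain at the limit, with an estimated step that the limit leaves unreadable from compound 3 to compound 4 that carries little meaning. The estimate for compound 4 is 30000 nM, in the range 8000 nM to 150000 nM.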

Compound 4, half-maximal inhibitory concentration: > 20000 nM
Compound 4 was reported as a limit; the forecaster's own chance of this, stated with the estimate: 85%; the middle value does not contradict the limit.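

Going by these compounds alone, compound 4, like compound 2 and compound 3, gives only a limit in this assay and so no step among them can be read. How strongly any of these compounds inhibits stays open, with every value at the same limit: the limit of > 20000 nM in this assay, at which 4 of the 4 values shown sit.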